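A few compounds are considered here, and "the series" means these few. Any claim that something is new, unique, unknown or untested is made for them only; others in the source may bear on it.

Measured so far in an assay on isolated protein for inhibition of proto-oncogene tyrosine-protein kinase receptor Ret variant V804M (Homo sapiens), read by 33P incorporation, with stated times of 15 min and 40 min; on this read-out lower numbers stand for stronger inhibition and higher numbers for weaker inhibition: compound 1 `Cc1ccc(F)c(NC(=O)Nc2ccc(Nc3ncnc4c3OCCN4)cc2)c1` gives 5110 nM. Compound 2 `O=C(Nc1ccc(Nc2ncnc3c2OCCN3)cc1)Nc1cccc2ccccc12` gives > 10000 nM, which is a limit of this assay. Compound 3 `O=C(Nc1ccc(Nc2ncnc3c2OCCN3)cc1)Nc1cccs1` gives 8640 nM.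

Compound 3 stands nearest compound 1, the step of a 1.7-fold higher number from compound 1 to compound 3 (0.23 log units; within the scatter) lying within the scatter; its comparison with compound 2 rests on a limit (the limit of > 10000 nM in this assay, at which 1 of the 3 values shown sits).

Compound 4 `CC(C)(C)c1csc(NC(=O)Nc2ccc(Nc3ncnc4c3OCCN4)cc2)n1` differs from compound 3 by 4-(tert-butyl)-1,3-thiazol-2-yl in place of thiophen-2-yl on an amide-type nitrogen. Among the compounds with values here, the steps that bear on this change are the earlier swaps on the same amide-type nitrogen, a 1.7-fold higher number from compound 1 to compound 3 (0.23 log units; within the scatter) and an at least 1.1-fold lower number from compound 2 to compound 3 (0.06 log units; that floor lies within the scatter), neither of which reached beyond the scatter. For compound 4 no step beyond the scatter is therefore expected in this assay, an expected change of a 1.1-fold lower number from compound 3 to compound 4 (0.03 log units; within the scatter). Compound 4 is thus estimated at 8000 nM, between 3000 nM and 20000 nM.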

Compound 4, half-maximal inhibitory concentration: 5170 nM
For compound 4 the middle estimate is 1.5-fold (0.19 log units) above the measured one; the range from low to high includes it.
By their numbers in this assay, from the lowest: compounds 1, 4 and 3 (each within the scatter of the next). At a limit, above all of these: compound 2.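

Placing 4-(tert-butyl)-1,3-thiazol-2-yl on the amide-type nitrogen, a substituted five-membered aromatic ring with 2 hetero atoms, moves nothing beyond the scatter in this assay (a 1.7-fold lower number from compound 3 to compound 4 (0.22 log units; within the scatter)) and (a 1.0-fold higher number from compound 1 to compound 4 (0.01 log units; within the scatter)). The step (an at least 1.9-fold lower number from compound 2 to compound 4 (0.28 log units; that floor lies within the scatter)) starts from a limit, not a number. So far, no swap shown at this nitrogen reaches beyond the scatter, even with this added tert-butyl.

As far as these compounds go, whether an amine, a carboxylic acid or a longer alkyl chain on this nitrogen would bring a step beyond the scatter stays open. So does whether any group here can give much stronger inhibition.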